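Secondary to Tertiary Amine on the Shared Core

The source may report more compounds than this note shows. Statements on the series, on what has been measured and on what is new or still open speak of the compounds shown alone.

Measured compounds:
compound 1 `COc1ccccc1-c1cc(C2CCNC2)ccc1Cl`: 400 nM
compound 2 `CCCCNCc1ccc(Cl)c(-c2ccccc2OC)c1`: 240 nM

In an assay on isolated protein for binding affinity to 5-hydroxytryptamine receptor 6 (Homo sapiens) (a lower number here means a stronger inhibitor, a higher number a weaker inhibitor), compound 2 gives the lower of the two numbers, yet the step of a 1.7-fold lower number from compound 1 to compound 2 (0.22 log units; within the scatter) stays within the scatter, so compounds 1 and 2 cannot be told apart. Compound 3 `CCN(CC)Cc1ccc(Cl)c(-c2ccccc2OC)c1` differs from compound 2 by diethylamino in place of butylamino on a saturated chain carbon bound to an aromatic carbon. Within the data shown here, no measured step repeats this change; the only step, a 1.7-fold lower number from compound 1 to compound 2 (0.22 log units; within the scatter), swapped a different amine and moved little. With no evidence for a shift, the step of a 1.3-fold higher number from compound 2 to compound 3 (0.10 log units; within the scatter) is expected to stay within the scatter. Compound 3 is therefore estimated at 300 nM, within 100 nM to 900 nM.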

Compound 3, inhibition constant: 2000 nM
Beside the measured number, compound 3's estimate is 6.7-fold (0.82 log units) below it; the measured number lies above the stated range.
By their numbers in this assay, from the lowest: compounds 2 and 1 (each within the scatter of the next); then compound 3.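

In this assay, the amine on this saturated chain carbon clearly matters: diethylamino in place of butylamino, with the same count of heavy atoms, brings an 8.3-fold higher number from compound 2 to compound 3 (0.92 log units; beyond the scatter), a real loss of binding. The (diethylamino)methyl group also stands apart from pyrrolidin-3-yl, with a 5.0-fold higher number from compound 1 to compound 3 (0.70 log units; beyond the scatter), whereas (butylamino)methyl could not be told from pyrrolidin-3-yl. Nothing in hand gives a reason for this loss. As far as these compounds go, whether dimethylamino, piperidin-1-yl or a longer chain such as hexylamino on the same carbon would behave like butylamino or like diethylamino stays open.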